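The source may hold more compounds than are shown below. What is called first, only, known or untested is meant among the compounds shown, and "the series" means these compounds.

Compounds measured in a functional assay on HCT-116 cells (Homo sapiens) for inhibition, read by MTT assay, with a stated time of 72 h; a lower number here means a stronger inhibitor, a higher number a weaker inhibitor:
- compound 1 `Cc1ccc(CN2CCc3ncn(COCc4ccccc4)c3/C(=C/c3ccccc3)C2=O)cc1`: 7940 nM
- compound 2 `CC(C)(C)c1ccc(CN2CCc3ncn(COCc4ccccc4)c3/C(=C/c3ccccc3)C2=O)cc1`: 8460 nM

Going by the values given here, compound 2, at 8460 nM, lies within the scatter of compound 1, the only other measured compound. Compound 3 `O=C1/C(=C\c2ccccc2)c2c(ncn2COCc2ccccc2)CCN1Cc1ccc2ccccc2c1` differs from compound 2 by naphthalen-2-yl in place of 4-(tert-butyl)phenyl on a saturated chain carbon bound to an amide-type nitrogen in a ring.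

Among the compounds with values here, the only measured step is a 1.1-fold higher number from compound 1 to compound 2 (0.03 log units; within the scatter), with tert-butyl in place of methyl on an aromatic carbon. Within the data shown here, it stays within the scatter, but it bears only loosely on this change, and no measured compound carries naphthalen-2-yl. With that single step as a guide, no step beyond the scatter is expected in this assay, and no direction is favoured. The estimated step is a 1.1-fold lower number from compound 2 to compound 3 (0.05 log units; within the scatter). For compound 3 the expected value is 7500 nM, with an estimated range of 3500 nM to 16000 nM.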

Compound 3, half-maximal inhibitory concentration: 19400 nM
For compound 3 the middle estimate is 2.6-fold (0.41 log units) below the measured one; measured number outside the range, above it.
By their numbers in this assay, from the lowest: compounds 1 and 2 (each within the scatter of the next); then compound 3.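

At the position on a saturated chain carbon bound to an amide-type nitrogen in a ring, this assay does respond to the aryl group: naphthalen-2-yl in place of 4-(tert-butyl)phenyl gives a 2.3-fold higher number from compound 2 to compound 3 (0.36 log units; beyond the scatter), and naphthalen-2-yl in place of 4-methylphenyl gives a 2.4-fold higher number from compound 1 to compound 3 (0.39 log units; beyond the scatter). Both steps are modest but beyond the scatter and point towards a weaker inhibitor, so this position is not indifferent to every aryl group, even though the exchange of methyl for tert-butyl left the number within the scatter and the two groups exchanged in the first step have the same count of heavy atoms. Nothing available explains this shift.

Still open, from the compounds shown here alone, is whether naphthalen-1-yl would give a number like that of naphthalen-2-yl. Also open, going by these compounds, is whether an amine or a carboxylic acid in place of the methyl of compound 1 would move the number in either direction.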